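Replacing the naphthalen-2-yl group of compound 1

The source may hold more compounds than are shown below. What is called first, only, known or untested is meant among the compounds shown, and "the series" means these compounds.

- compound 1 `COC(=O)c1scc(-c2ccc(NC(=O)c3ccc4ccccc4c3)cc2)c1OC` gives 10300 nM
- compound 2 `COC(=O)c1scc(-c2ccc(NC(=O)c3cccc(I)c3)cc2)c1OC` gives 14700 nM
- compound 3 `COC(=O)c1scc(-c2ccc(NC(=O)c3cccc(OC(F)(F)F)c3)cc2)c1OC` gives 18300 nM

In a functional assay on K562 cells (Homo sapiens) for antiproliferative activity, read by MTT assay, with a stated time of 24 h (on this read-out higher numbers stand for weaker inhibition and lower numbers for stronger inhibition), compound 1 gives 10300 nM, which stands level with the other two compounds within the scatter. The unmeasured compound 4 `COC(=O)c1scc(-c2ccc(NC(=O)c3cc(I)ccc3F)cc2)c1OC` differs from it as follows: 2-fluoro-5-iodophenyl in place of naphthalen-2-yl on a carbonyl carbon. Here, 2-fluoro-5-iodophenyl replaces naphthalen-2-yl on a carbonyl carbon. The nearest evidence is a 1.4-fold higher number from compound 1 to compound 2 (0.15 log units; within the scatter), where 3-iodophenyl replaces the same group. A second change, a 1.2-fold higher number from compound 2 to compound 3 (0.10 log units; within the scatter), puts trifluoromethoxy in place of iodo. No step beyond the scatter is therefore expected in this assay. The estimated change is a 1.4-fold higher number from compound 1 to compound 4 (0.13 log units; within the scatter). For compound 4 the expected value is 14000 nM, within an estimated range of 7000 nM to 28000 nM.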

Compound 4, half-maximal inhibitory concentration: 35600 nM
Estimate against measurement, compound 4: 2.5-fold (0.41 log units) below; the whole stated range lies below it.
By their numbers in this assay, from the lowest: compounds 1, 2, 3 and 4 (each within the scatter of the next, the first and the last beyond it).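

For the compounds shown here, the aryl group on this carbonyl carbon is less tolerant than the earlier compounds suggested. Adding a single fluoro in place of hydrogen on an aromatic carbon gives a 2.4-fold higher number from compound 2 to compound 4 (0.38 log units; beyond the scatter), the first single change from compound 2 to go beyond the scatter. Taken together, 2-fluoro-5-iodophenyl in place of naphthalen-2-yl gives a 3.5-fold higher number from compound 1 to compound 4 (0.54 log units; beyond the scatter), and no available evidence accounts for this difference. The compounds shown leave open whether fluoro would give a similar step without the iodo group. They also leave open what a methoxy group or an amine would give in place of that fluoro.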